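This account rests on a few compounds, and the source may have more. Where it says the series, first, only, none or still open, it means among the compounds named here.

In an ADME assay on the whole organism (Rattus norvegicus) for pharmacokinetics, read by LC-MS, at a dose of 5 mg/kg by the oral route; on this read-out higher numbers stand for higher oral bioavailability and lower numbers for lower oral bioavailability:

Compound 1 `CNC(=O)c1c(-c2ccc(F)cc2)oc2cc(N(Cc3ccc(B(O)O)c(F)c3)S(C)(=O)=O)c(C3CC3)cc12` gives 23%
Compound 2 `CNC(=O)c1c(-c2ccc(F)cc2)oc2cc(N3C(=O)OC[C@@H]3c3ccc(B(O)O)c(F)c3)c(C3CC3)cc12` gives 8%

Compound 1 stands highest of these two numbers; compound 2 lies lower by a margin beyond the usual scatter. Compound 3 `CNC(=O)c1c(-c2ccc(F)cc2)oc2cc(N(C3CCc4c(B(O)O)cccc43)S(C)(=O)=O)c(C3CC3)cc12` has not yet been measured in this assay. It differs from compound 1 by a group of 12 heavy atoms (9 carbon, 1 boron, 2 oxygen; one five-membered non-aromatic ring of carbon only, one six-membered aromatic ring of carbon only) in place of a group of 11 heavy atoms (7 carbon, 1 boron, 2 oxygen, 1 fluorine; one six-membered aromatic ring of carbon only), on a sulfonamide nitrogen. Within the data shown here, no measured pair shows what this kind of change does, so only a cautious expectation is possible: a step within the scatter or a modest fall. Compound 3 is expected to reach 18%, in a range from 5% to 35%. That corresponds to an expected step of a number 5 percentage points lower from compound 1 to compound 3 (within the scatter).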

Compound 3, oral bioavailability: 4%
Compound 3: the middle estimate sits 14 percentage points above what was measured; measured number outside the range, below it.
By their numbers in this assay, from the lowest: compounds 3 and 2 (each within the scatter of the next); then compound 1.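

In this assay, changing the group on the sulfonamide nitrogen gives a number 19 percentage points lower from compound 1 to compound 3 (beyond the scatter) when the group with a five-membered non-aromatic ring of carbon only replaces the one with fluorine. This shows that the number responds to the group at this position, even though the shared core stays the same and the counted donors and acceptors match. The compounds leave open whether the fluorine leaving or the new ring matters, and how a simple methyl or an amine at this position would read. No measurement shown here explains the fall.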